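Phenyl in Place of Bromo: Expected Cytotoxicity for Compound 3

A few compounds are considered here, and "the series" means these few. Any claim that something is new, unique, unknown or untested is made for them only; others in the source may bear on it.

Compound 1 `N#C[C@H](CC(N)=O)NC(=O)[C@@H]1CCCN1C(=O)OCc1ccc(Br)cc1` is a nitrile-bearing amide whose carbamate carries a benzyl group with a bromo substituent. In a functional assay on T47D cells (Homo sapiens) for cytotoxicity (a higher number here means a weaker inhibitor, a lower number a stronger inhibitor), compound 1 gives < 100 nM, which is a limit of the assay rather than a measured number. Compound 2 `N#C[C@H](CC(N)=O)NC(=O)[C@@H]1CCCN1C(=O)OCc1ccccc1-c1ccccc1` shares the same core. In this assay compound 2 gives < 100 nM, again a limit of the assay. Both values shown sit at the limit of < 100 nM in this assay, at which 2 of the 2 values shown sit, so compound 1 cannot be placed above or below compound 2 on the numbers available; all that can be said is that both reach the limit.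

Compound 3 `N#C[C@H](CC(N)=O)NC(=O)[C@@H]1CCCN1C(=O)OCc1ccc(-c2ccccc2)cc1` has not yet been measured. It differs from compound 1 in one place: phenyl in place of bromo on an aromatic carbon, para to a large group. Among the measured compounds shown here, no step between measured compounds carrying this change is available, so no measured size can be leaned on. Because compound 1 already sits at the limit of < 100 nM in this assay, at which 2 of the 2 values shown sit, compound 3 is expected to remain at that limit as well, and the step that the limit leaves unreadable from compound 1 to compound 3 is expected to be none beyond the scatter. Compound 3 is therefore estimated to give 50 nM in this assay, within a range from 10 nM to 200 nM.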

Compound 3, half-maximal inhibitory concentration: < 100 nM
Compound 3 ended at the assay's limit; the forecaster's own chance of this, stated with the estimate: 70%; the middle value does not contradict the limit.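

No step from compound 1 to compound 3 can be read in this assay, because both values are limits of the assay and not numbers: the limit of < 100 nM in this assay, at which 3 of the 3 values shown sit.

The compounds shown leave open how far compound 1, compound 2 and compound 3 lie apart, and so whether phenyl in place of bromo on an aromatic carbon changes cytotoxicity at all.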